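A few compounds are considered here, and "the series" means these few. Any claim that something is new, unique, unknown or untested is made for them only; others in the source may bear on it.

Compound 1, `COC(=O)c1ccc(-c2cnc3ncn(C(C)c4cc5cccnc5cc4F)c3n2)cc1F`, and compound 2, `CNC(=O)c1ccc(-c2cnc3ncn(C(C)c4cc5cccnc5cc4F)c3n2)cc1F`, share one core and differ in a single group. In a functional assay on NCI-H1993 cells (Homo sapiens) for inhibition, read by CCK-8 assay, with a stated time of 72 h (on this read-out higher numbers stand for weaker inhibition and lower numbers for stronger inhibition), compound 1 gives 60.2 nM, and in this assay compound 2 gives 32.7 nM. The change between them is methylamino in place of methoxy on a carbonyl carbon, and it made a 1.8-fold lower number from compound 1 to compound 2 (0.27 log units; within the scatter).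

Compound 3, `COC(=O)c1ccc(/C=N/CNC(C)c2ccc3ncccc3c2)cc1F`, is built on a different core; the difference between the two cores is not broken down here. In this assay, going by the values given here, compound 3 gives 1110 nM, which is the highest of the three numbers measured so far, standing beyond the scatter from both compound 1 and compound 2.

Compound 4, `CNC(=O)c1ccc(/C=N/CNC(C)c2ccc3ncccc3c2)cc1F`, has not yet been measured in this assay. It differs from compound 3 by methylamino in place of methoxy on a carbonyl carbon, the same change that separates compound 2 from compound 1, since the two place lines read alike. Across the compounds shown this change occurs twice in all. Because compound 1 to compound 2 gave a 1.8-fold lower number from compound 1 to compound 2 (0.27 log units; within the scatter), a step that stays within the scatter, a step of about the same small size is expected for compound 4, namely a 1.6-fold lower number from compound 3 to compound 4 (0.20 log units; within the scatter). On that basis compound 4 is estimated to give 700 nM in this assay, with the expected range running from 250 nM to 2000 nM.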

Compound 4, half-maximal inhibitory concentration: 191 nM
Estimate against measurement, compound 4: 3.7-fold (0.56 log units) above; the whole stated range lies above it.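

In this assay, methylamino in place of methoxy on a carbonyl carbon gave a 5.8-fold lower number from compound 3 to compound 4 (0.76 log units; beyond the scatter), a step beyond the scatter, whereas the same change on the core of compound 1 gave a step that stayed within it. The size of the step therefore did not carry over from one core to the other, and the two cores cannot be treated as interchangeable for this change: the same change on two cores in this assay, a 1.8-fold lower number (0.27 log units; within the scatter) from compound 1 to compound 2 and a 5.8-fold lower number (0.76 log units; beyond the scatter) from compound 3 to compound 4, 3.2-fold (0.50 log units) apart, beyond the scatter of two such steps. Going by these compounds alone, this rests on only two matched pairs, so it shows that the core can matter to the size of the step, but it does not show which part of the difference between the two cores is responsible, nor how the change would behave on any third core.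

The compounds shown leave open how other groups on the same carbonyl carbon, such as a free carboxylic acid, a dimethylamino group or an ethylamino group, would read on either core. They also leave open whether the larger step seen with compound 4 would persist on a core that combines parts of the two shown here, which would help to locate the source of the gap.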